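This account rests on a few compounds, and the source may have more. Where it says the series, first, only, none or still open, it means among the compounds named here.

In a toxicity assay on cells (Fibroblast, Homo sapiens) for cytotoxicity (on this read-out lower numbers stand for stronger inhibition and higher numbers for weaker inhibition), compound 1 `COc1cccc(O)c1C(=O)OC/C=C(C)/C=C/C=C(C)/C=C/C1=CCCCC1(C)C` gives 230000 nM. Compound 2 `CC(/C=C/C1=CCCCC1(C)C)=C\C=C\C(C)=C\COC(=O)c1cccc(O)c1O` gives < 10000 nM, which is a limit of the assay and not a number. Its true position is therefore unknown, although the two results already define an at least 23-fold lower number from compound 1 to compound 2 (1.36 log units; beyond the scatter).

Compound 3 `CC(=O)Oc1ccccc1C(=O)OC/C=C(C)/C=C/C=C(C)/C=C/C1=CCCCC1(C)C` has not yet been measured. Compared with compound 2, it has 2-acetoxyphenyl in place of 2,3-dihydroxyphenyl on a carbonyl carbon.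

Among the compounds with values here, the only measured step that bears on this change is an at least 23-fold lower number from compound 1 to compound 2 (1.36 log units; beyond the scatter), which introduced the 2,3-dihydroxyphenyl group that compound 3 lacks. A large move toward a higher number, meaning weaker inhibition, is therefore expected in this assay, although its exact size remains uncertain. The expected change is an at least 8.0-fold higher number from compound 2 to compound 3 (0.90 log units; beyond the scatter). For compound 3, the estimated value is 80000 nM, with an expected range of 20000 nM to 300000 nM.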

Compound 3, half-maximal inhibitory concentration: 150000 nM
Estimate against measurement, compound 3: 1.9-fold (0.27 log units) below; low and high end bracket the measured number.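

Within this assay, replacing 2,3-dihydroxyphenyl with 2-acetoxyphenyl on a carbonyl carbon gives an at least 15-fold higher number from compound 2 to compound 3 (1.17 log units; beyond the scatter), so the step seen on first introducing the 2,3-dihydroxyphenyl group is reversed by a different group at the same place. The second comparison, a 1.5-fold lower number from compound 1 to compound 3 (0.19 log units; within the scatter), shows that 2-acetoxyphenyl and 2-hydroxy-6-methoxyphenyl cannot be told apart here, even though they are different groups. Among the three compounds shown, only the one carrying 2,3-dihydroxyphenyl stands apart in this read-out.

Compound 2 is known only as a limit of the assay, so the true size of both of its steps stays open: the limit of < 10000 nM in this assay, at which 1 of the 3 values shown sits.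
Also open, on these data alone, is whether the low number depends on the 2,3-dihydroxyphenyl group alone, or whether an aminophenyl or a carboxyphenyl group at this place would give a similar result.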